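A few compounds are considered here, and "the series" means these few. Any claim that something is new, unique, unknown or untested is made for them only; others in the source may bear on it.

The study compares three measured compounds built on one shared core. Compound 1 `Cc1ccc(-c2ccc([N+](=O)[O-])cc2)n1-c1ccc(-c2nc3ccccc3s2)cc1` gives 2540 nM in a functional assay on MCF7 cells (Homo sapiens) for cytotoxicity, read by sulforhodamine B assay, with a stated time of 48 h; on this read-out lower numbers stand for stronger inhibition of growth and higher numbers for weaker inhibition of growth. Compound 2 `COc1ccc2nc(-c3ccc(-n4c(C)ccc4-c4ccc([N+](=O)[O-])cc4)cc3)sc2c1` differs from compound 1 only by a methoxy in place of hydrogen on an aromatic carbon; in this assay compound 2 gives 3170 nM, and the step of a 1.2-fold higher number from compound 1 to compound 2 (0.10 log units; within the scatter) lies within the scatter. Compound 3 `COc1cc2nc(-c3ccc(-n4c(C)ccc4-c4ccc(C)cc4)cc3)sc2c(OC)c1OC` gives 2910 nM in this assay. On these numbers compound 3 sits close to both of the others: its gap to compound 2 and its gap to compound 1 are each within the scatter, so the three measured compounds cannot be told apart on this read-out.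

Compound 4 `COc1cc2nc(-c3ccc(-n4c(C)ccc4-c4ccc(F)cc4)cc3)sc2c(OC)c1OC` differs from compound 3 by fluoro in place of methyl on an aromatic carbon. Among the compounds with values here, no measured step concerns this change: the one step that has been measured touches a methoxy on the core, not the 4-methylphenyl group, and it stayed within the scatter. There is therefore nothing in the data to suggest a step beyond the scatter in this assay in either direction. The expected step is a 1.0-fold higher number from compound 3 to compound 4 (0.01 log units; within the scatter). Compound 4 is estimated to give 3000 nM, with a range from 1500 nM to 6000 nM.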

Compound 4, concentration for 50% growth inhibition: 2670 nM
Estimate against measurement, compound 4: 1.1-fold (0.05 log units) above; the range from low to high includes it.
By their numbers in this assay, from the lowest: compounds 1, 4, 3 and 2 (each within the scatter of the next).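

In this assay, within the data shown here, the exchange of the 4-methylphenyl group for 4-fluorophenyl gives a 1.1-fold lower number from compound 3 to compound 4 (0.04 log units; within the scatter), which is the first reading of any change at this place, on an aromatic carbon para to a large group. Among these compounds, the only earlier step concerned a methoxy on the core, so the result extends the picture to a second place on the molecule: here too the step stays within the scatter, and methyl and fluoro cannot be told apart on this read-out with the trimethoxy-substituted core of compound 3 and compound 4. There is no measured information on why these two groups read alike.

Among the compounds shown here, whether an amine, a carboxylic acid or a longer chain at this place would give a step beyond the scatter remains open, since methyl and fluoro are the only two groups compared here on an otherwise unchanged structure. Also open, going by these compounds, is whether the same exchange of methyl for fluoro would stay within the scatter on the core of compound 1, which carries no methoxy groups.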